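From 3,4-Dimethoxyphenyl to Pyridin-2-yl on a Shared Core

The source may report more compounds than this note shows. Statements on the series, on what has been measured and on what is new or still open speak of the compounds shown alone.

Values from an ADME assay on HEK293 cells (Homo sapiens) for cytotoxicity, read by MTT assay, with a stated time of 48 h (on this read-out lower numbers stand for stronger inhibition and higher numbers for weaker inhibition), are known for three compounds that share one core.

- compound 1 `Cc1ccc(/C=C2/S/C(=N/c3ccccc3)N(Cc3ccncc3)C2=O)cc1` gives 49500 nM
- compound 2 `CN(C)c1ccc(/C=C2/S/C(=N/c3ccccc3)N(Cc3ccncc3)C2=O)cc1` gives 122000 nM
- compound 3 `COc1ccc(/C=C2/S/C(=N/c3ccccc3)N(Cc3ccncc3)C2=O)cc1OC` gives 171000 nM

Compound 3 sits at the high end of this small set. Two steps fix its place: a 1.4-fold higher number from compound 2 to compound 3 (0.15 log units; within the scatter) and a 3.5-fold higher number from compound 1 to compound 3 (0.54 log units; beyond the scatter).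

Compound 4 `O=C1/C(=C\c2ccccn2)S/C(=N/c2ccccc2)N1Cc1ccncc1` has not been measured yet. It carries pyridin-2-yl in place of 3,4-dimethoxyphenyl on a double-bonded chain carbon bound to a double-bonded ring carbon.

Among the measured compounds shown here, no measured compound has a pyridin-2-yl group at this place, so the evidence is indirect. The nearest guide is the set of changes to the group at this place, which also includes a 2.5-fold higher number from compound 1 to compound 2 (0.39 log units; beyond the scatter) as a modest step. None of these steps is large, so only a small step is expected in this assay. A slight lean towards a lower number seems fair, since compound 1 at 49500 nM shows that this series can read well under compound 3 at 171000 nM as a value.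

The estimated step is a 1.9-fold lower number from compound 3 to compound 4 (0.28 log units; within the scatter) as a working expectation. For compound 4 the expected value is 90000 nM, with an estimated range from 35000 nM to 220000 nM as its likely span.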

Compound 4, half-maximal inhibitory concentration: 161000 nM
Beside the measured number, compound 4's estimate is 1.8-fold (0.25 log units) below it; low and high end bracket the measured number.
By their numbers in this assay, from the lowest: compound 1; then compounds 2, 4 and 3 (each within the scatter of the next).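

In this assay, pyridin-2-yl in place of 3,4-dimethoxyphenyl gives a 1.1-fold lower number from compound 3 to compound 4 (0.03 log units; within the scatter), which means that going from 10 heavy atoms to 6, with a nitrogen now in the aromatic ring, leaves the number within the scatter. Against the 4-(dimethylamino)phenyl group the picture is the same, with a 1.3-fold higher number from compound 2 to compound 4 (0.12 log units; within the scatter), while the 4-methylphenyl group stays apart, with a 3.3-fold higher number from compound 1 to compound 4 (0.51 log units; beyond the scatter), a modest step beyond the scatter; among these four compounds, compounds 2, 3 and 4 read alike, and compound 1 alone gives a lower number. The earlier compounds carried only carbon rings at this place, and compound 4 adds a ring with a hetero atom to the group that reads alike, though nothing measured here explains why the groups sort in this way.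

Still open, from the compounds shown here alone, is whether the low number of compound 1 is special to 4-methylphenyl or would also appear with a plain phenyl or a 4-chlorophenyl group. Going by these compounds, it is also open whether pyridin-3-yl or pyridin-4-yl would read like pyridin-2-yl, and whether a group carrying a carboxylic acid would stay with compounds 2, 3 and 4.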